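Removing the pyridinyl ring: stability of compound 4

A few compounds are considered here, and "the series" means these few. Any claim that something is new, unique, unknown or untested is made for them only; others in the source may bear on it.

Measured so far:
- compound 1, `CCCCc1nc(=O)c(S(=O)(=O)c2ccc(-c3cccnc3)cc2)c(O)n1-c1c(OC)cccc1OC`: 57%
- compound 2, `CCCCc1[nH]c(=O)c(S(=O)(=O)c2ccc(-c3ccc(F)cc3)cc2)c(O)c1-c1c(OC)cccc1OC`: "not determined" (no result reported)
- compound 3, `COc1cccc(OC)c1-n1c(COC(C)C)nc(=O)c(S(=O)(=O)c2ccc(-c3ccc(F)nc3)cc2)c1O`: 90%

In an ADME assay on microsomes from liver (Mus musculus) for metabolic stability, using NADPH, with a stated time of 10 min (a lower number here means that less of the compound is left, a higher number that more of the compound is left), compound 1 gives 57%. For the measured compounds named here, this is the lower of the two numbers known: compound 3 gives 90% in this assay, and the gap between compound 1 and compound 3 lies beyond the scatter. Compound 2 was not examined in this assay, so no number is available for it.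

Compound 4, `CCCCc1nc(=O)c(S(=O)(=O)c2ccccc2)c(O)n1-c1c(OC)cccc1OC`, differs from compound 1 in one place: hydrogen in place of pyridin-3-yl on an aromatic carbon. Going by the values given here, no pair of measured compounds shows this particular change, so no measured step tells how large an effect to expect. Among the compounds with values here, with only a single comparable number in hand, the expectation for compound 4 is that the step of a number 2 percentage points lower from compound 1 to compound 4 (within the scatter) stays within the scatter of repeated measurements. On that basis the estimated value for compound 4 in this assay is 55%, with a likely range from 35% to 75%.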

Compound 4, percent of the compound remaining: 79%
Estimate against measurement, compound 4: 24 percentage points below; the measured number lies above the stated range.
By their numbers in this assay, from the lowest: compound 1; then compound 4; then compound 3.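

Removing the pyridin-3-yl group and leaving hydrogen on the aromatic carbon gives a number 22 percentage points higher from compound 1 to compound 4 (beyond the scatter) in this assay, so the outer ring is not needed for the compound to persist in this test. This position therefore matters for the read-out, and the change from 4-(pyridin-3-yl)phenyl to phenyl leaves more of the compound intact. The earlier compounds shown here could not show this, as no two of them differed only here.

As far as these compounds go, it remains open whether a group smaller than the pyridin-3-yl ring, such as an amine or a carboxylic acid on the same carbon, would keep the gain. One step on one core also cannot show whether the same removal would help in compounds with a different chain. Nothing available explains why the number rises with this change.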